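Removing One Methyl From a Carboxy Side Chain

This account rests on a few compounds, and the source may have more. Where it says the series, first, only, none or still open, it means among the compounds named here.

In an ADME assay on cells (Hepatocyte, Homo sapiens) for metabolic stability, read by LC-MS, with a stated time of 180 min, tested at 1 uM (on this read-out higher numbers stand for fast clearance and lower numbers for slow clearance), compound 2 `CC(C)(C(=O)O)c1nn(Cc2cn3cc(OCC4CC4)c(Cl)cc3n2)c2ccccc2c1=O` gives < 10 mL/min/kg. That value is a limit of the assay and not a number, so compound 2 has no exact clearance to start from. Compound 1 `O=C(O)Cc1nn(Cc2cn3cc(OCC4CC4)c(Cl)cc3n2)c2ccccc2c1=O` gives < 6.67 mL/min/kg, which is also a limit. Compound 3 `CC(C(=O)O)c1nn(Cc2cn3cc(OCC4CC4)c(C(F)(F)F)cc3n2)c2ccccc2c1=O`, which carries a 1-carboxyethyl group on a different core, gives < 8.34 mL/min/kg, again a limit.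

Compound 4 `C[C@H](C(=O)O)c1nn(Cc2cn3cc(OCC4CC4)c(Cl)cc3n2)c2ccccc2c1=O` is related to compound 2 by a single structural change: 1-carboxyethyl in place of 1-carboxy-1-methylethyl on an aromatic carbon. In words, 1-carboxyethyl stands in place of 1-carboxy-1-methylethyl on an aromatic carbon, and the new group has a defined stereocentre.

Among the compounds with values here, the one measured step at this same place is a step that the two limits leave unreadable from compound 1 to compound 2, where 1-carboxy-1-methylethyl replaces carboxymethyl. Both ends of that step are limits, so it gives neither a size nor a direction to carry over. In this assay, no change beyond the usual scatter is therefore expected, and the estimated step is a step that the limit leaves unreadable from compound 2 to compound 4. The assay may well report only a limit again. For compound 4, the expected clearance is about 6 mL/min/kg, with an estimated range of 3 mL/min/kg to 10 mL/min/kg.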

Compound 4, clearance: 6.67 mL/min/kg
For compound 4 the middle estimate is 1.1-fold (0.05 log units) below the measured one; the range from low to high includes it.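

In this assay compound 4 gives 6.67 mL/min/kg, the first exact number among the compounds shown, so a 1-carboxyethyl group at this position on this core now has a measured clearance.

Compound 1 is still known only as a limit. With methyl in place of hydrogen on a saturated chain carbon bound to an aromatic carbon and a carbonyl carbon, the result is a number no lower from compound 1 to compound 4 (the limit leaves the size open), so no size can be given to the effect of this methyl. For the change from 1-carboxy-1-methylethyl to 1-carboxyethyl, the size stays open because compound 2 also has only a limit: the limit of < 10 mL/min/kg in this assay, at which 1 of the 4 values shown sits.

On these data alone, it remains open how the mirror-image form of the 1-carboxyethyl group in compound 4 would read in this assay. Also open, as far as these compounds go, is whether a longer chain ending in a carboxylic acid, or an amide in place of the acid, would give a clearance that could be compared directly with compound 4.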